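The compounds below may be only part of what the source reports. "The series", "measured", "known", "first", "only" and "open" are said of these compounds alone.

Measured compounds:
Compound 1, `CCCc1nc(CC)c(C(=O)OCCC[S+]([O-])c2ccccc2)n1Cc1ccc(-c2ccccc2S(=O)(=O)NC(=O)OCCC(C)C)cc1F`: 1 nM
Compound 2, `CCCCCCCOC(=O)NS(=O)(=O)c1ccccc1-c1ccc(Cn2c(CCC)nc(CC)c2C(=O)OCc2ccccc2OC)c(F)c1`: 10 nM

Both compounds were tested in an assay on isolated protein for binding affinity to Type-2 angiotensin II receptor (Homo sapiens); on this read-out lower numbers stand for stronger inhibition and higher numbers for weaker inhibition. Going by the values given here, of the two numbers, compound 1 stands lowest; the only neighbour, compound 2, gives a number that lies well above it, beyond the usual scatter of repeated measurements.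

Compound 3, `CCCc1nc(CC)c(C(=O)OCCCN2C(=O)c3ccccc3C2=O)n1Cc1ccc(-c2ccccc2S(=O)(=O)NC(=O)OCCC(C)C)cc1F`, has not yet been measured. It differs from compound 1 in a single place: a group of 11 heavy atoms (8 carbon, 1 nitrogen, 2 oxygen; one five-membered non-aromatic ring with 1 hetero atom, one six-membered aromatic ring of carbon only) in place of a group of 8 heavy atoms (6 carbon, 1 oxygen, 1 sulfur; one six-membered aromatic ring of carbon only), on a saturated chain carbon, three bonds along the chain from an oxygen next to a carbonyl group.

Among the compounds with values here, no measured pair isolates a change of this kind, so the expectation rests on the two values at hand. The group that leaves and the group that enters are both of moderate size and neither carries a charge, so a modest step is expected, most likely toward a somewhat higher number. The step from compound 1 to compound 3 is estimated at a 2.5-fold higher number from compound 1 to compound 3 (0.40 log units; beyond the scatter). For compound 3 the expected value is 2.5 nM, with a range from 0.6 nM to 10 nM.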

Compound 3, half-maximal inhibitory concentration: 3 nM
Beside the measured number, compound 3's estimate is 1.2-fold (0.08 log units) below it, and the stated range covers the measured number.
By their numbers in this assay, from the lowest: compound 1; then compound 3; then compound 2.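

In this assay, replacing the sulfur-bearing group with the larger group containing a five-membered non-aromatic ring gives a 3.0-fold higher number from compound 1 to compound 3 (0.48 log units; beyond the scatter), the first step shown that isolates a change at this place on the chain. The step lies beyond the usual scatter but is modest, so this saturated chain position accepts two quite different uncharged end groups, and compound 3 still gives 3 nM. No measurement here explains why the number rises with this change.

The compounds shown leave open how an amine, a carboxylic acid or a plain phenyl group would behave at this same place, and what a shorter or longer linking chain would do. They also leave open whether this swap would give a similar step on a different core.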